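The source may report more compounds than this note shows. Statements on the series, on what has been measured and on what is new or still open speak of the compounds shown alone.

Measured in a functional assay on DU-145 cells (Homo sapiens) for cytotoxicity; a lower number here means a stronger inhibitor of growth, a higher number a weaker inhibitor of growth:
- compound 1 `CSc1ccc(C2=C(c3ccc(F)c(C)c3)C(=O)N3CCCC3C2)cc1`: 500 nM
- compound 2 `COc1ccc(C2=C(c3ccc(SC)cc3)CC3CCCN3C2=O)cc1`: 900 nM
- compound 3 `CSc1ccc(C2=C(c3ccc(OCC4CO4)cc3)C(=O)N3CCCC3C2)cc1`: 500 nM

In this assay compound 3 gives 500 nM, the same number at the digits shown as compound 1. Together they hold the lowest number of the three, and the gap to compound 2 at 900 nM stays within the scatter.

The next compound is compound 4 `CSc1ccc(C2=C(c3ccc(C)cc3)C(=O)N3CCCC3C2)cc1`, with methyl in place of (oxiran-2-yl)methoxy on an aromatic carbon.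

Both measured steps changed this same aryl group, and both are small: a 1.8-fold higher number from compound 1 to compound 2 (0.26 log units; within the scatter) and a 1.8-fold lower number from compound 2 to compound 3 (0.26 log units; within the scatter). Neither step left the scatter, so the three different aryl groups measured so far do not separate in this assay. Compound 1 also carries a methyl on this aryl group, together with a fluorine, and gives 500 nM. Among the measured compounds shown here, no measured compound has the methyl alone on this ring, so the support is indirect.

No shift beyond the scatter is expected, and the estimated step is a 1.2-fold higher number from compound 3 to compound 4 (0.08 log units; within the scatter). For compound 4 the expected value is 600 nM, with an estimated range of 250 nM to 1400 nM.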

Compound 4, concentration for 50% growth inhibition: 600 nM
Compound 4: middle estimate and measured number agree at the digits printed; measured number inside the range.
By their numbers in this assay, from the lowest: compounds 1, 3, 4 and 2 (each within the scatter of the next).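

Replacing (oxiran-2-yl)methoxy with methyl in this assay gives a 1.2-fold higher number from compound 3 to compound 4 (0.08 log units; within the scatter), so removing the three-membered ring and both hydrogen-bond acceptors of that group, and going from 5 heavy atoms to 1, does not carry the result beyond the scatter at this aromatic carbon. Among the compounds shown here, the two smaller changes read the same way: methyl in place of methoxy gives a 1.5-fold lower number from compound 2 to compound 4 (0.18 log units; within the scatter), and 4-methylphenyl in place of 4-fluoro-3-methylphenyl gives a 1.2-fold higher number from compound 1 to compound 4 (0.08 log units; within the scatter), which adds the direct reading on methyl alone that the earlier compounds lacked. No data given here explain why these steps are so small.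

On these data alone, all four aryl groups on this carbon now fall within the scatter of one another, but each carries no net charge and no hydrogen-bond donor, so it remains open whether a primary amine or a carboxylic acid at this place would separate from them. The methylthio group on the other aryl ring is also common to compounds 1, 3 and 4, and compound 2 carries it too, so its replacement by a hydroxyl or a longer alkoxy chain remains an open question for this series.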